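This account rests on a few compounds, and the source may have more. Where it says the series, first, only, none or still open, it means among the compounds named here.

Of the compounds shown here, three have so far been measured in an ADME assay on the whole organism with Oryza sativa as the target, tested at 10 uM; on this read-out higher numbers stand for a weaker effect at the one concentration tested and lower numbers for a stronger effect. Compound 1 `CCc1ccccc1NC(=O)N[C@@H](C)c1ccccc1` gives 95%, compound 2 `C[C@H](NC(=O)Nc1ccccc1C(C)(C)C)c1ccccc1` gives 100%, and compound 3 `COc1ccccc1NC(=O)N[C@H](C)c1ccccc1` gives 96%. Going by the values given here, the only step between compounds that differ in a single place, a number 5 percentage points higher from compound 1 to compound 2 (within the scatter), stays within the scatter. Compound 3 sits close to both of them, its number within the scatter of compound 1 and of compound 2 alike. Compound 4 `COc1ccccc1NC(=O)N[C@@H](C)c1ccccc1` is not yet measured; it differs from compound 3 in this way: the two compounds have the same atoms and bonds and differ only in configuration as drawn: 1 of 1 stereo elements differ; a stereocentre at a saturated chain carbon is drawn R in compound 3 and S in compound 4. Among the compounds with values here, no measured step changes configuration alone, so nothing bears directly on this change, and the small step from compound 1 to compound 2 gives no direction either. A step of no change at the digits printed from compound 3 to compound 4 (within the scatter) is therefore expected, within the scatter. Compound 4 is estimated at 96%, between 88% and 100%.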

Compound 4, a percentage reported as activity, at one concentration (the size of the read-out at that concentration, not a potency): 95%
Compound 4: middle estimate off by 1 percentage points, on the high side, and the stated range covers the measured number.
By their numbers in this assay, from the lowest: compounds 1, 4, 3 and 2 (each within the scatter of the next).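

Drawing the stereocentre at the saturated chain carbon S rather than R gives a number 1 percentage points lower from compound 3 to compound 4 (within the scatter) in this assay, the first reading on configuration alone, and this pair isolates that change: the fact that compounds 3 and 4 differ only in the configuration as drawn. Methoxy also reads alike with the other groups on the aromatic carbon: in place of ethyl it gives no change at the digits printed from compound 1 to compound 4 (within the scatter) and in place of tert-butyl it gives a number 5 percentage points lower from compound 2 to compound 4 (within the scatter).

From the compounds shown here alone, whether an amine or a carboxylic acid on that aromatic carbon would move the number beyond the scatter stays open. So does whether configuration would matter in a compound with a clearly stronger effect.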